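A few compounds are considered here, and "the series" means these few. Any claim that something is new, unique, unknown or untested is made for them only; others in the source may bear on it.

Compound 1 `COc1cc(-c2cc(/C=C/C(=O)c3ccc(Cl)c(Cl)c3)[nH]n2)cc(OC)c1OC`: 5730 nM
Compound 2 `COc1ccc(C(=O)/C=C/c2cc(-c3cc(OC)c(OC)c(OC)c3)n[nH]2)cc1OC`: 1280 nM

In a functional assay on UO-31 cells (Homo sapiens) for inhibition, read by sulforhodamine B assay, with a stated time of 48 h (a lower number here means a stronger inhibitor of growth, a higher number a weaker inhibitor of growth), compound 1 gives 5730 nM and compound 2 gives 1280 nM. Compound 2 stands with the lower of the two numbers, set apart from compound 1 by the step of a 4.5-fold lower number from compound 1 to compound 2 (0.65 log units; beyond the scatter). Compound 3 `COc1cc(-c2cc(/C=C/C(=O)c3ccc(F)c(F)c3)[nH]n2)cc(OC)c1OC` differs from compound 2 in one place: 3,4-difluorophenyl in place of 3,4-dimethoxyphenyl on a carbonyl carbon. Within the data shown here, the one measured step that bears on this change is a 4.5-fold lower number from compound 1 to compound 2 (0.65 log units; beyond the scatter), in which a 3,4-dichlorophenyl on the same carbonyl carbon gave way to 3,4-dimethoxyphenyl. Moving back to a halogenated ring points to a higher number for compound 3 in this assay; no measured compound shows whether 3,4-difluorophenyl lands nearer to 3,4-dichlorophenyl or nearer to 3,4-dimethoxyphenyl. Compound 3 is therefore expected to give 3500 nM, within 1200 nM to 9000 nM. The expected step is a 2.7-fold higher number from compound 2 to compound 3 (0.44 log units; beyond the scatter), a rise beyond the scatter.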

Compound 3, concentration for 50% growth inhibition: 2630 nM
The estimate for compound 3 lay 1.3-fold (0.12 log units) above the measured number; measured number inside the range.
By their numbers in this assay, from the lowest: compound 2; then compound 3; then compound 1.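

In this assay, the place on the carbonyl carbon now has three measured groups, and the two halogen-bearing rings do not read alike: 3,4-difluorophenyl in place of 3,4-dichlorophenyl gives a 2.2-fold lower number from compound 1 to compound 3 (0.34 log units; beyond the scatter) and is thus a real gain among the halogens. Even so, the change from 3,4-dimethoxyphenyl gives a 2.1-fold higher number from compound 2 to compound 3 (0.31 log units; beyond the scatter), so compound 3 falls in the middle of the three and compound 2 keeps the lowest number. Nothing measured here accounts for this order.

The compounds shown leave open whether an unsubstituted phenyl, a 4-methoxyphenyl or a 3,4-dihydroxyphenyl on the carbonyl carbon would fall lower than compound 2. They also leave open whether the same order of the three rings would hold with a different group elsewhere on the shared core.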